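The source may report more compounds than this note shows. Statements on the series, on what has been measured and on what is new or still open speak of the compounds shown alone.

Compound 1 `Cc1cc(C)cc(Cc2ccc3c(NCCCNCc4ccco4)ccnc3c2)c1` was measured in an ADME assay for permeability, using PAMPA, with a stated time of 30 min, at pH 7.4 (a lower number here means that the compound crosses the layer more slowly, a higher number that the compound crosses the layer faster), where it gives 23 10^-6 cm/s. This is the lowest of three numbers, shared with compound 3 `CC(C)CCc1ccc2c(NCCCNCc3ccco3)ccnc2c1`, which gives 23 10^-6 cm/s; compound 2 `CN(C)c1cccc(Oc2ccc3c(NCCCNCc4ccco4)ccnc3c2)c1` gives 317 10^-6 cm/s. The two measured steps beyond the scatter, a 14-fold higher number from compound 1 to compound 2 (1.14 log units; beyond the scatter) and a 14-fold lower number from compound 2 to compound 3 (1.14 log units; beyond the scatter), both alter the group on the aromatic carbon of the shared core, while no change at the digits printed from compound 1 to compound 3 (within the scatter) shows that swapping an aryl for an alkyl piece at the benzylic carbon leaves the reading untouched. Compound 4 `COc1ccc(F)cc1CNCCCNc1ccnc2cc(Cc3cc(C)cc(C)c3)ccc12` instead differs from compound 1 at the other end of the chain: 5-fluoro-2-methoxyphenyl in place of furan-2-yl on a saturated chain carbon bound to an amine nitrogen. Going by the values given here, no measured step touches this position, so a small change within the scatter is expected. Compound 4 is expected to give about 30 10^-6 cm/s, between 12 10^-6 cm/s and 75 10^-6 cm/s. That estimate amounts to a 1.3-fold higher number from compound 1 to compound 4 (0.12 log units; within the scatter).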

Compound 4, apparent permeability: 23 10^-6 cm/s
Beside the measured number, compound 4's estimate is 1.3-fold (0.12 log units) above it; the range from low to high includes it.
By their numbers in this assay, from the lowest: compounds 1, 3 and 4 (each within the scatter of the next); then compound 2.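

Going by these compounds alone, the step of no change at the digits printed from compound 1 to compound 4 (within the scatter) is the first reading in this assay for a change at this end of the chain. A furan-2-yl of 5 heavy atoms gives way here to a six-membered 5-fluoro-2-methoxyphenyl of 9 heavy atoms, and the size of the group does not show in the number for this pair. No measured evidence accounts for this result.

Still open, on these data alone, is whether a carboxylic acid or a longer alkyl chain in this place would shift the number. Also open, as far as these compounds go, is whether the same swap behaves alike on the core of compound 2.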